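The source may report more compounds than this note shows. Statements on the series, on what has been measured and on what is new or still open speak of the compounds shown alone.

Compound 1 `O=C1/C(=C/c2ccccc2F)CCc2ccccc21`: 20800 nM
Compound 2 `O=C1/C(=C/c2ccccc2[N+](=O)[O-])CCc2ccccc21`: 7220 nM

In a functional assay on CCRF-CEM cells (Homo sapiens) for inhibition (on this read-out higher numbers stand for weaker inhibition and lower numbers for stronger inhibition), compound 2 holds the lowest of the two numbers shown; its nearest neighbour is compound 1, and the step from compound 1 to compound 2 was a 2.9-fold lower number from compound 1 to compound 2 (0.46 log units; beyond the scatter). Compound 3 `Cc1ccccc1/C=C1\CCc2ccccc2C1=O` differs from compound 2 by methyl in place of nitro on an aromatic carbon. Within the data shown here, the only measured step bears on this change in reverse: the nitro that came in with a 2.9-fold lower number from compound 1 to compound 2 (0.46 log units; beyond the scatter) now leaves, and methyl, not fluoro, takes its place. The number for compound 3 is therefore expected to rise back toward compound 1, a step of about a 2.1-fold higher number from compound 2 to compound 3 (0.32 log units; beyond the scatter). The estimate for compound 3 is 15000 nM, ranging from 5000 nM to 45000 nM.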

Compound 3, half-maximal inhibitory concentration: 43200 nM
The estimate for compound 3 lay 2.9-fold (0.46 log units) below the measured number, within the range that was stated.
By their numbers in this assay, from the lowest: compound 2; then compound 1; then compound 3.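

With a third group at this place on the aromatic ring, the numbers in this assay run from nitro through fluoro to methyl, so the group carried here clearly matters. Methyl in place of nitro gives a 6.0-fold higher number from compound 2 to compound 3 (0.78 log units; beyond the scatter) and does more than undo the earlier gain, since methyl in place of fluoro still gives a 2.1-fold higher number from compound 1 to compound 3 (0.32 log units; beyond the scatter) as well. No measurement here accounts for this order. On these data alone, whether an amine or a carboxylic acid at this place would give a lower number than compound 2 stays open, as does whether the same order would hold elsewhere on the ring.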